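Methyl Added Along the Amine Chain of Quinazolinol Analogues

This account rests on a few compounds, and the source may have more. Where it says the series, first, only, none or still open, it means among the compounds named here.

Measured compounds:
- compound 1, `Oc1nc(NCC2CCCCC2)nc2ccc(Cl)cc12`, 23900 nM
- compound 2, `C[C@H](Nc1nc(O)c2cc(Cl)ccc2n1)C1CCCCC1`, 15100 nM
- compound 3, `CC(C)Nc1nc(O)c2cc(I)ccc2n1`, 44100 nM

All three compounds were tested in a functional assay (ileum) for inhibition, with Cavia porcellus as the target; on this read-out lower numbers stand for stronger inhibition and higher numbers for weaker inhibition. Compound 1 gives 23900 nM, and its partner compound 2, which carries one extra methyl, gives 15100 nM. The change between them is methyl in place of hydrogen on a saturated chain carbon bound to a nitrogen on an aromatic ring and a saturated ring carbon and the step it made was a 1.6-fold lower number from compound 1 to compound 2 (0.20 log units; within the scatter). Compound 3, with 44100 nM, has the highest number of the three, yet its gap to compound 1 is within the scatter and only its gap to compound 2 lies beyond it. The difference between the core of compound 1 and the core of compound 3 is not broken down here.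

Compound 4, `CCC(C)Nc1nc(O)c2cc(I)ccc2n1`, has not yet been measured. It differs from compound 3 by methyl in place of hydrogen on a saturated chain carbon, two bonds along the chain from a nitrogen on an aromatic ring. Within the data shown here, this is the same kind of change as the one from compound 1 to compound 2, but not the same: there the methyl entered on a saturated chain carbon bound to a nitrogen on an aromatic ring and a saturated ring carbon, whereas here it enters on a saturated chain carbon two bonds along the chain from a nitrogen on an aromatic ring. Among the measured compounds shown here, the one measured example of such a change, a 1.6-fold lower number from compound 1 to compound 2 (0.20 log units; within the scatter), stayed within the scatter, so for compound 4 a step of about a 1.5-fold lower number from compound 3 to compound 4 (0.17 log units; within the scatter) is expected, resting on that single precedent and on the number of compound 3, 44100 nM. Compound 4 is therefore estimated at 30000 nM, within a range from 10000 nM to 90000 nM.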

Compound 4, half-maximal inhibitory concentration: 23600 nM
The estimate for compound 4 lay 1.3-fold (0.10 log units) above the measured number; the measured number falls inside the stated range.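

In this assay, placing a methyl on a saturated chain carbon, two bonds along the chain from a nitrogen on an aromatic ring, gives a 1.9-fold lower number from compound 3 to compound 4 (0.27 log units; within the scatter), so this step cannot be told apart from the ordinary differences between repeated measurements. Set beside the earlier step, it shows that the change behaved much alike on the two cores, with neither step standing out from the other: the same change on two cores in this assay, a 1.6-fold lower number (0.20 log units; within the scatter) from compound 1 to compound 2 and a 1.9-fold lower number (0.27 log units; within the scatter) from compound 3 to compound 4, 1.2-fold (0.07 log units) apart, within the scatter of two such steps This agreement shows only that the methyl produced no step beyond the scatter in either pair; it does not show that the methyl truly strengthens inhibition, and two pairs, in which the methyl does not sit in an identical place, do not make a rule for the whole series.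

On these data alone, whether an ethyl group, a longer chain or a carboxylic acid on this same chain carbon would give a step beyond the scatter remains open. Also open, as far as these compounds go, is whether the methyl would behave in the same way on a third core, such as one with a fluorine in place of the iodine of compound 4.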